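Thiazolyl replacement of the difluorophenyl on the cyclopropane

The compounds below may be only part of what the source reports. "The series", "measured", "known", "first", "only" and "open" are said of these compounds alone.

Three compounds of the series carry numbers in a functional assay for agonist activity at G protein-coupled receptor 88 (Homo sapiens), read by HTRF and cAMP accumulation; on this read-out higher numbers stand for an effect only at larger amounts of compound and lower numbers for an effect already at smaller amounts. Within the data shown here, compound 1 `CN[C@@H](CC(C)C)CN(C(=O)[C@@H]1C[C@H]1c1ccccc1)c1ccc(-c2ccccc2)cc1` gives 2 nM, and compound 2 `O=C([C@@H]1C[C@H]1c1ccccc1)N(CCNCC1CCCC1)c1ccc(-c2ccccc2)cc1` gives 2.5 nM; the one step that joins them, a 1.3-fold higher number from compound 1 to compound 2 (0.10 log units; within the scatter), concerns only the amine-bearing side chain. Compound 3 `CC[C@H](C)[C@H](N)CN(C(=O)[C@@H]1C[C@H]1c1cc(F)ccc1F)c1ccc(-c2ccccc2)cc1` gives 770 nM, the highest of the three numbers, far beyond the scatter from both compound 2 and compound 1. Compound 4 `CC[C@H](C)[C@H](N)CN(C(=O)[C@@H]1C[C@H]1c1nc(C)c(C)s1)c1ccc(-c2ccccc2)cc1` differs from compound 3 in one place: 4,5-dimethyl-1,3-thiazol-2-yl in place of 2,5-difluorophenyl on a saturated ring carbon. Among the measured compounds shown here, no measured pair alters the group on the cyclopropane, so the single step on record, from compound 1 to compound 2, does not bear on this change, and there is no precedent for the direction or size of the effect in this assay. Compound 4 is therefore expected near compound 3, with a wide range, and its step of a 1.3-fold higher number from compound 3 to compound 4 (0.11 log units; within the scatter) is estimated to lie within the scatter. The estimate for compound 4 in this assay is 1000 nM, between 150 nM and 6000 nM.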

Compound 4, half-maximal effective concentration: 3600 nM
Compound 4: the middle estimate sits 3.6-fold (0.56 log units) below what was measured, and the stated range covers the measured number.
By their numbers in this assay, from the lowest: compounds 1 and 2 (each within the scatter of the next); then compound 3; then compound 4.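

Among these compounds, the group on the cyclopropane is the first place where a single change moves the number beyond the scatter in this assay: a 4.7-fold higher number from compound 3 to compound 4 (0.67 log units; beyond the scatter). Exchanging 2,5-difluorophenyl for 4,5-dimethyl-1,3-thiazol-2-yl, a five-membered aromatic ring with 2 hetero atoms, therefore costs potency in this pair, although the step is modest beside the much larger gap that separates compound 3 from compound 1 and compound 2. No measurement at hand accounts for this step.

Open, from the compounds shown here alone, is whether the ring itself or its two methyl groups carries the step, a question that an unsubstituted 1,3-thiazol-2-yl or a pyridin-2-yl at this place would address. Also open, going by these compounds, is whether the step keeps its size with the methylamino side chain of compound 1 and an unsubstituted phenyl as the reference group.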